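This account rests on a few compounds, and the source may have more. Where it says the series, first, only, none or still open, it means among the compounds named here.

Working notes on the quinoline-derived thiosemicarbazone series in a functional assay on SGC-7901 cells (Homo sapiens) for antiproliferative activity, read by sulforhodamine B assay, with a stated time of 72 h; a lower number here means a stronger inhibitor, a higher number a weaker inhibitor.

Of the compounds shown here, two of this set have a value so far. Compound 1, `COc1cccc(NC(=S)N/N=C/c2ccc3ccccc3n2)c1`, gives 79400 nM in this assay, the highest of the two numbers recorded. Among the measured compounds shown here, compound 2, `CN(C)C(=S)N/N=C/c1ccc2cccnc2n1`, gives 630 nM in this assay, a far lower number than that of compound 1 and well beyond the scatter; compound 2 differs from compound 1 in more than one place, so nothing in the present data isolates which part of that difference carries the gap, and no step between the two is counted here.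

The next compound, compound 3, `S=C(NCc1ccccc1)N/N=C/c1ccc2ccccc2n1`, is compared with compound 1 and differs from it in a single place: benzyl in place of 3-methoxyphenyl on an amide-type nitrogen. The substituent on the amide-type nitrogen is the only thing that moves; the core and the hydrazone linkage are the same as in compound 1.

For the measured compounds named here, no measured pair isolates this exact change, so the expectation rests on compound 1 alone, whose value of 79400 nM in this assay sets the starting point. For compound 3 the step from compound 1 is expected to be a 4.0-fold lower number from compound 1 to compound 3 (0.60 log units; beyond the scatter), a move toward a lower number, with considerable uncertainty. Compound 3 is therefore estimated at 20000 nM in this assay, within a range from 3000 nM to 100000 nM.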

Compound 3, half-maximal inhibitory concentration: 53700 nM
Estimate against measurement, compound 3: 2.7-fold (0.43 log units) below; measured number inside the range.
By their numbers in this assay, from the lowest: compound 2; then compounds 3 and 1 (each within the scatter of the next).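

In this assay, among the compounds shown here, benzyl in place of 3-methoxyphenyl on the amide-type nitrogen gives a 1.5-fold lower number from compound 1 to compound 3 (0.17 log units; within the scatter), the first single-place step, and it stays within the scatter. This position therefore tolerates this exchange without a measurable change in the number: a six-membered aromatic ring of carbon only is present on both sides of the step, while the hydrogen-bond acceptor of 3-methoxyphenyl is absent from benzyl. The data on hand offer no explanation for this result, and a single step with two aromatic substituents supports no general rule for this position.

The compounds shown leave open whether any substituent on this nitrogen can move the number beyond the scatter on this core, for example a longer chain such as phenethyl or a benzyl ring carrying a carboxylic acid. For the compounds shown here, the much lower number of compound 2 also remains unassigned, as no single-place step connects it to either of the other compounds.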